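The compounds below may be only part of what the source reports. "The series", "measured", "known", "first", "only" and "open" are said of these compounds alone.

The series keeps one core, joined through an amide to a ring amine, and varies only the group on that ring nitrogen. Compound 1 `CCN1CCN(CC(=O)Nc2nc3ccccc3[nH]2)CC1` carries ethyl there, compound 2 `O=C(CN1CCN(c2ccccc2F)CC1)Nc1nc2ccccc2[nH]1` carries 2-fluorophenyl and compound 3 `O=C(CN1CCN(c2ccccn2)CC1)Nc1nc2ccccc2[nH]1` carries pyridin-2-yl. In a functional assay, read by spectrophotometry, with a stated time of 30 min, tested at 5 ug/mL (a higher number here means a stronger effect of the compound at the concentration tested, a lower number a weaker effect), compound 1 gives 13.3%, compound 2 gives 11.6% and compound 3 gives 30.8%. The step of a number 1.7 percentage points lower from compound 1 to compound 2 (within the scatter) lies within the scatter, so compounds 1 and 2 are not told apart. Compound 3 stands highest of the three: the steps of a number 17.5 percentage points higher from compound 1 to compound 3 (beyond the scatter) and a number 19.2 percentage points higher from compound 2 to compound 3 (beyond the scatter) are both beyond the scatter, though modest.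

Compound 4 `O=C(CN1CCN(c2ccc([N+](=O)[O-])cc2)CC1)Nc1nc2ccccc2[nH]1` is not yet measured. The change is 4-nitrophenyl in place of pyridin-2-yl on an amine nitrogen in a ring. Going by the values given here, the steps that bear on it are those into compound 3, since each also swaps the group on the ring nitrogen: a number 17.5 percentage points higher from compound 1 to compound 3 (beyond the scatter) and a number 19.2 percentage points higher from compound 2 to compound 3 (beyond the scatter). In both the higher number sits with the six-membered aromatic ring with one hetero atom, and the carbon-only ring of compound 2 sits with the lower numbers. Among the compounds with values here, no step from pyridin-2-yl to a carbon-only ring bearing a nitro group is on record, so the size is uncertain. Within the data shown here, a fall back toward compound 2 is expected, but only a modest one is estimated, since the nitro group has no precedent here: a number 12.8 percentage points lower from compound 3 to compound 4 (beyond the scatter). For compound 4 in this assay the expected value is 18%, between 7% and 32%.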

Compound 4, a percentage reported as activity, at one concentration (the size of the read-out at that concentration, not a potency): 16.1%
The estimate for compound 4 lay 1.9 percentage points above the measured number; low and high end bracket the measured number.
By their numbers in this assay, from the lowest: compounds 2, 1 and 4 (each within the scatter of the next); then compound 3.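

In this assay, 4-nitrophenyl on the amine nitrogen in a ring does not keep the level of pyridin-2-yl: the step is a number 14.7 percentage points lower from compound 3 to compound 4 (beyond the scatter), so a second carbon-only aromatic ring, with a different group on it from 2-fluorophenyl, also sits below compound 3. The steps of a number 4.5 percentage points higher from compound 2 to compound 4 (within the scatter) and a number 2.8 percentage points higher from compound 1 to compound 4 (within the scatter) do not tell compound 4 apart from either neighbour, so ethyl, 2-fluorophenyl and 4-nitrophenyl form one level, and among these four compounds only pyridin-2-yl stands clear of the others, which also means that an aromatic ring at this position is not enough on its own, as compound 2 and compound 4 show. No measurement bears on why the number falls with this change.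

Open, going by these compounds, is whether the ring nitrogen of pyridin-2-yl carries the higher number, and whether pyridin-4-yl or pyrimidin-2-yl at this position would reach the level of compound 3 at 30.8%. Also open, on these data alone, is whether an unsubstituted phenyl, or an amine on the carbon-only ring in place of nitro, would stay at the lower level.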